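This account rests on a few compounds, and the source may have more. Where it says the series, first, only, none or still open, it means among the compounds named here.

Compound 2 `Nc1ccccc1NC(=O)c1ccc(CNC(=O)c2n[nH]cc2NC(=O)c2c(Cl)cccc2Cl)cc1` in a functional assay on A-375 cells (Homo sapiens) for inhibition, read by CCK-8 assay, with a stated time of 72 h (on this read-out higher numbers stand for weaker inhibition and lower numbers for stronger inhibition), gives 1200 nM, level with compound 1 `Nc1ccccc1NC(=O)c1ccc(CNC(=O)c2n[nH]cc2NC(=O)c2c(F)cccc2Cl)cc1`, which in this assay gives 1200 nM; the step of no change at the digits printed from compound 1 to compound 2 (within the scatter) is the only one measured and it lies within the scatter. Compound 3 `Nc1ccccc1NC(=O)c1ccc(CNC(=O)c2n[nH]cc2NC(=O)c2c(F)cccc2F)cc1` differs from compound 2 at one place: 2,6-difluorophenyl in place of 2,6-dichlorophenyl on a carbonyl carbon. The measured step bears on this change directly, since it swapped one halogen at the same ring without effect, so the second swap is expected to give no step beyond the scatter, no change at the digits printed from compound 2 to compound 3 (within the scatter). Compound 3 is therefore estimated at 1200 nM, within 600 nM to 2400 nM.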

Compound 3, half-maximal inhibitory concentration: 1700 nM
For compound 3 the middle estimate is 1.4-fold (0.15 log units) below the measured one, within the range that was stated.
By their numbers in this assay, from the lowest: compounds 1, 2 and 3 (each within the scatter of the next).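

In this assay the exchange of both chloro groups for fluoro gives a 1.4-fold higher number from compound 2 to compound 3 (0.15 log units; within the scatter), and the exchange of a single chloro group gives a 1.4-fold higher number from compound 1 to compound 3 (0.15 log units; within the scatter). On this carbonyl carbon, the 2,6-difluorophenyl and 2,6-dichlorophenyl groups and the ring carrying one of each halogen therefore cannot be told apart, so the halogen exchange now reads as tolerated across all three compounds. Nothing available explains this flat result.

The compounds shown leave open whether a phenyl ring without halogen, or one carrying methyl or methoxy groups instead, stays at this level. Any halogen larger than chloro, such as bromo, also remains open.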